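The compounds below may be only part of what the source reports. "The series", "measured", "known", "first", "only" and "open" are said of these compounds alone.

Compound 3 `Cc1ccc(N2C(=O)[C@H]3[C@H](ON4[C@@H]3C(=O)N(C)[C@@]43C[C@H](C)CC[C@H]3C(C)C)C2=O)c(C)c1` gives 57% in a functional assay, with a stated time of 20 min, tested at 1 mg/mL (a higher number here means a stronger effect of the compound at the concentration tested, a lower number a weaker effect), the highest of the three numbers shown, while compound 2 `COc1ccc(N2C(=O)[C@H]3[C@H](ON4[C@@H]3C(=O)N(C)[C@@]43C[C@H](C)CC[C@H]3C(C)C)C2=O)cc1` gives 48.1% and compound 1 `CC(C)[C@@H]1CC[C@@H](C)C[C@@]12N(C)C(=O)[C@@H]1[C@H]3C(=O)N(C)C(=O)[C@H]3ON12` gives 43.1%. Among the compounds with values here, only the step of a number 13.9 percentage points higher from compound 1 to compound 3 (beyond the scatter) lay beyond the scatter; the steps of a number 5 percentage points higher from compound 1 to compound 2 (within the scatter) and a number 8.9 percentage points higher from compound 2 to compound 3 (within the scatter) did not. Compound 4 `CC(C)[C@@H]1CC[C@@H](C)C[C@@]12N(C)C(=O)[C@@H]1[C@H]3C(=O)N(c4ccc5ccccc5c4)C(=O)[C@H]3ON12` differs from compound 3 by naphthalen-2-yl in place of 2,4-dimethylphenyl on an amide-type nitrogen in a ring. Within the data shown here, the steps that bear on this are the two aryl-for-methyl replacements at the same amide-type nitrogen in a ring and the one exchange of aryl for aryl, which stayed within the scatter. A further aryl exchange at that position is therefore expected to shift this assay little, a number 1 percentage points higher from compound 3 to compound 4 (within the scatter). Compound 4 is estimated at 58%, between 42% and 72%.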

Compound 4, a percentage reported as activity, at one concentration (the size of the read-out at that concentration, not a potency): 27.6%
Compound 4: the middle estimate sits 30.4 percentage points above what was measured; the measured number lies below the stated range.
By their numbers in this assay, from the lowest: compound 4; then compounds 1, 2 and 3 (each within the scatter of the next, the first and the last beyond it).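

At the amide-type nitrogen in a ring, aryl groups proved not to be interchangeable in this assay: naphthalen-2-yl brought a number 29.4 percentage points lower from compound 3 to compound 4 (beyond the scatter) and a number 20.5 percentage points lower from compound 2 to compound 4 (beyond the scatter) so an aryl exchange here can carry the read-out beyond the scatter. Aryl in place of methyl does not always raise the number either, for naphthalen-2-yl brought a number 15.5 percentage points lower from compound 1 to compound 4 (beyond the scatter) and so goes against the rise seen with 2,4-dimethylphenyl. Nothing measured here accounts for this fall. On these data alone, it remains open whether the second aromatic ring or the loss of the two methyl groups matters more. As far as these compounds go, how a benzyl group or an unsubstituted phenyl would read at this nitrogen also remains open.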